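This account rests on a few compounds, and the source may have more. Where it says the series, first, only, none or still open, it means among the compounds named here.

Measured in a functional assay on the whole organism (strain Kunming) with Mus musculus as the target, in the formalin test, with a stated time of 0.5 h; a higher number here means that more compound is needed for the effect, a lower number that less compound is needed:
- compound 1 `COc1cc(OC)c(OC)cc1/C=C/COC(=O)/C=C/c1ccccc1C(F)(F)F`: 123 mg/kg
- compound 2 `COc1cc(OC)c(OC)cc1/C=C/COC(=O)/C=C/c1cc(OC)c(OC)c(OC)c1`: 85.5 mg/kg
- compound 3 `COc1cc(OC)c(OC)cc1/C=C/COC(=O)/C=C/c1ccc(OC)c(OC)c1OC`: 78.4 mg/kg

Compound 1, at 123 mg/kg, has the highest number of the three, but its gaps to compound 2 and compound 3 lie within the usual scatter, so the data do not set it apart from either.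

The next compound to be tested is compound 4 `COc1cccc(/C=C/C(=O)OC/C=C/c2cc(OC)c(OC)cc2OC)c1`. It keeps the core of compound 1 and carries 3-methoxyphenyl in place of 2-(trifluoromethyl)phenyl on a double-bonded chain carbon bound to a double-bonded chain carbon. Among the measured compounds shown here, no measured pair isolates this change, so the evidence is indirect. Compound 2 at 85.5 mg/kg and compound 3 at 78.4 mg/kg also replace the trifluoromethyl group with methoxy groups, and neither leaves the scatter around compound 1. In this assay, no step beyond the scatter is therefore expected, and the expected change is a 1.4-fold lower number from compound 1 to compound 4 (0.14 log units; within the scatter). For compound 4 the estimated value is 90 mg/kg, with an expected range from 50 mg/kg to 160 mg/kg.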

Compound 4, dose for half-maximal effect: > 100 mg/kg
Compound 4 gave a limit, no number; the forecaster's own chance of this, stated with the estimate: 5%; at least 1.1-fold (0.04 log units) between middle value and limit.
By their numbers in this assay, from the lowest: compounds 3, 2 and 1 (each within the scatter of the next).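

In this assay compound 4 gives > 100 mg/kg, which is a limit and not a number. Among the compounds shown here, no step from compound 1 to compound 4 can therefore be read. The compounds shown leave open whether, and in which direction, 3-methoxyphenyl in place of 2-(trifluoromethyl)phenyl shifts the dose needed.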